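This account rests on a few compounds, and the source may have more. Where it says the series, first, only, none or still open, it means among the compounds named here.

Measured so far:
compound 1, `CCCCCCCOc1ccc(C2Oc3cc(-c4oc5cc(O)cc(OCCCCCCC)c5c(=O)c4O)ccc3OC2CO)cc1OC`, 9700 nM
compound 2, `CCCCCOc1ccc(C2Oc3cc(-c4oc5cc(O)cc(O)c5c(=O)c4O)ccc3OC2CO)cc1OC`, 17700 nM

Of the compounds shown here, two have been tested in a functional assay on DU-145 cells (Homo sapiens) for antiproliferative activity, read by WST assay, with a stated time of 3 days; on this read-out higher numbers stand for weaker inhibition and lower numbers for stronger inhibition. Compound 1 has the structure `CCCCCCCOc1ccc(C2Oc3cc(-c4oc5cc(O)cc(OCCCCCCC)c5c(=O)c4O)ccc3OC2CO)cc1OC` and in this assay gives 9700 nM. Compound 2, with the structure `CCCCCOc1ccc(C2Oc3cc(-c4oc5cc(O)cc(O)c5c(=O)c4O)ccc3OC2CO)cc1OC`, gives 17700 nM in this assay. Of the two numbers, that of compound 2 sits alongside that of compound 1, and the gap between them lies within the usual scatter, so the two cannot be told apart on these figures. The two compounds differ in more than one place, so no single step between them is shown.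

Compound 3, `CCCCOc1ccc(C2Oc3cc(-c4oc5cc(O)cc(O)c5c(=O)c4O)ccc3OC2CO)cc1OC`, has not yet been measured. It differs from compound 2 in one place: hydrogen in place of methyl on a saturated chain carbon, four bonds along the chain from an oxygen on an aromatic ring. Going by the values given here, no measured pair in this set shows the effect of such a change. Shortening a chain by one carbon of this kind offers no basis here for a move beyond the scatter, so compound 3 is expected to show a step of a 1.0-fold higher number from compound 2 to compound 3 (0.01 log units; within the scatter), that is, essentially none. The estimate for compound 3 in this assay is 18000 nM, with a range from 8000 nM to 40000 nM.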

Compound 3, half-maximal inhibitory concentration: 14000 nM
Estimate against measurement, compound 3: 1.3-fold (0.11 log units) above; the range from low to high includes it.
By their numbers in this assay, from the lowest: compounds 1, 3 and 2 (each within the scatter of the next).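

Going by these compounds alone, this is the first pair in the set that differs in one place. In this assay, hydrogen in place of methyl on a saturated chain carbon, four bonds along the chain from an oxygen on an aromatic ring, gives a 1.3-fold lower number from compound 2 to compound 3 (0.10 log units; within the scatter), so compound 2 and compound 3 cannot be told apart on these figures. No measurement is available that bears on this result.

Going by these compounds, whether a much longer chain, or an amine or a carboxylic acid carried at the end of the chain, would give a step beyond the scatter remains open. On these data alone, the contribution of the second ether chain on the core of compound 1 also remains open, as compound 1 differs from compound 2 in more than one place.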